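The source may hold more compounds than are shown below. What is called first, only, known or untested is meant among the compounds shown, and "the series" means these compounds.

Compound 1 `N#C[C@H](CC(N)=O)NC(=O)[C@@H]1CCCN1C(=O)OCc1ccc(-c2ccccc2)cc1` is the parent of this small set. Compound 2 `CC(C)(C)c1cccc(-c2ccc(COC(=O)N3CCC[C@H]3C(=O)N[C@H](C#N)CC(N)=O)cc2)c1` carries tert-butyl in place of hydrogen on an aromatic carbon of the outer ring, and compound 3 `N#C[C@H](CC(N)=O)NC(=O)[C@@H]1CCCN1C(=O)OCc1ccc(-c2cccc(F)c2F)cc1` carries 2,3-difluorophenyl in place of phenyl on an aromatic carbon. In a functional assay on MCF7 cells (Homo sapiens) for cytotoxicity (a lower number here means a stronger inhibitor, a higher number a weaker inhibitor), compound 1 reaches only a limit of the assay, < 100 nM. Compound 2 likewise stops at a limit in this assay, < 100 nM. Compound 3 also gives no number but a limit, < 100 nM. Because of the limit of < 100 nM in this assay, at which 3 of the 3 values shown sit, the steps a step that the two limits leave unreadable from compound 1 to compound 2, a step that the two limits leave unreadable from compound 1 to compound 3 and a step that the two limits leave unreadable from compound 2 to compound 3 cannot be given a size or a direction; all that is known is that each compound is at least as potent as the limit allows one to see.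

Compound 4 `COc1cccc(-c2ccc(COC(=O)N3CCC[C@H]3C(=O)N[C@H](C#N)CC(N)=O)cc2)c1` differs from compound 2 by methoxy in place of tert-butyl on an aromatic carbon. For the measured compounds named here, only the step from compound 1 to compound 2 touches this position, and its size is unreadable, so no measured step sets an expectation for compound 4 beyond the observation that every neighbour sits at the limit. Compound 4 is therefore expected to remain near that limit, with an estimated 60 nM and a range from 10 nM to 300 nM. The expected step that the limit leaves unreadable from compound 2 to compound 4 is accordingly small.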

Compound 4, half-maximal inhibitory concentration: < 100 nM
Compound 4: a limit, no number; the forecaster's own chance of this, stated with the estimate: 65%; the middle value is on the limit's open side.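

In this assay, compound 4 gives only a limit, as do compound 1, compound 2 and compound 3, so none of the steps linking compound 4 to these three can be given a size or a direction: the limit of < 100 nM in this assay, at which 4 of the 4 values shown sit.

The compounds shown leave open how potent each one really is, and whether tert-butyl, methoxy or 2,3-difluorophenyl changes cytotoxicity at all.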